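The compounds below may be only part of what the source reports. "The series", "measured", "known", "first", "only" and "open" are said of these compounds alone.

Measured compounds:
compound 1 `O=C(O)[C@@H]1CCCN1C(=O)CN(c1nc(Cl)nc2[nH]cnc12)C1CC1` — 23.6%
compound 2 `O=C(CN(c1nc(Cl)nc2[nH]cnc12)C1CC1)NCC(=O)OCc1ccccc1` — 21.7%
compound 3 `O=C(O)CNC(=O)CN(c1nc(Cl)nc2[nH]cnc12)C1CC1` — 19.8%

All three numbers come from a functional assay on the whole organism (Tail, strain ICR) with Mus musculus as the target, in the tail flick test, with a stated time of 120 min, at a dose of 25 umol/kg by the oral route; a lower number here means a weaker effect, a higher number a stronger effect of the compound at the dose given. They lie close together: the step of a number 3.8 percentage points lower from compound 1 to compound 3 (within the scatter) and the step of a number 1.9 percentage points lower from compound 2 to compound 3 (within the scatter) are both within the scatter, so compound 3 cannot be separated from compound 1 or from compound 2 on these numbers, even though its figure is the smallest of the three.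

Compound 4 `O=C(O)C[C@H](NC(=O)CN(c1nc(Cl)nc2[nH]cnc12)C1CC1)C(=O)O` is the next compound to be measured. It differs from compound 3 by carboxymethyl in place of hydrogen on a saturated chain carbon bound to an amide-type nitrogen and a carbonyl carbon.

Both measured steps touch the same end of the molecule as this change, the acid-bearing part joined through the amide. Neither the exchange of the ring acid for the chain acid, a number 3.8 percentage points lower from compound 1 to compound 3 (within the scatter), nor the removal of the benzyl from the ester oxygen, a number 1.9 percentage points lower from compound 2 to compound 3 (within the scatter), moved the read-out beyond the scatter. Adding a further carboxymethyl at the chain carbon is therefore expected to give no step beyond the scatter in this assay .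

Compound 4 is expected to give 20%, with a range from 10% to 30%. The expected step is a number 0.2 percentage points higher from compound 3 to compound 4 (within the scatter).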

Compound 4, a percentage reported as activity, at one dose (the size of the read-out at that dose, not a potency): 22%
Beside the measured number, compound 4's estimate is 2 percentage points below it; measured number inside the range.
By their numbers in this assay, from the lowest: compounds 3, 2, 4 and 1 (each within the scatter of the next).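

In this assay, carboxymethyl in place of hydrogen on a saturated chain carbon bound to an amide-type nitrogen and a carbonyl carbon gives a number 2.2 percentage points higher from compound 3 to compound 4 (within the scatter) and stays within the scatter. The earlier steps shown here exchanged the ring acid for the chain acid or removed the benzyl from the ester oxygen, whereas this step adds a group at the chain carbon itself, turning carboxymethyl into 1,2-dicarboxyethyl, and the read-out still cannot be separated from that of compound 3. Nothing available explains the size of this step.

Going by these compounds, whether an amine, a phenyl group or a longer chain ending in a carboxylic acid at this chain carbon would give a step beyond the scatter remains open. The compounds shown also leave open whether the shared core tolerates changes elsewhere, such as replacing the cyclopropyl group.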